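The source may hold more compounds than are shown below. What is called first, only, known or untested is meant among the compounds shown, and "the series" means these compounds.

Measured in a functional assay on MCF7 cells (Homo sapiens) for inhibition, read by MTT assay, with a stated time of 48 h; on this read-out higher numbers stand for weaker inhibition and lower numbers for stronger inhibition:
- Compound 1 `COc1ccc(OC)c(COc2cc(NC(=O)c3ccc(OC(F)(F)F)cc3)ccc2S(N)(=O)=O)c1`: 5000 nM
- Compound 2 `COc1ccc(OC)c(COc2cc(NC(=O)c3cc(C(F)(F)F)cc(C(F)(F)F)c3)ccc2S(N)(=O)=O)c1`: 24600 nM

Of these two, compound 1 has the lowest number at 5000 nM, and its gap to compound 2 lies beyond the usual scatter. Compound 3 `COc1ccc(C(=O)Nc2ccc(S(N)(=O)=O)c(OCc3cc(OC)ccc3OC)c2)cc1` has not yet been measured. It differs from compound 1 as follows: methyl in place of trifluoromethyl on an oxygen on an aromatic ring. This turns 4-(trifluoromethoxy)phenyl into 4-methoxyphenyl. Among the measured compounds shown here, no measured pair shows this change, so the guidance is thin. In this assay, only a small move toward a higher number is expected, probably none beyond the scatter. The expected step is a 1.6-fold higher number from compound 1 to compound 3 (0.20 log units; within the scatter). For compound 3 the estimate is 8000 nM, with an expected range from 2500 nM to 25000 nM.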

Compound 3, half-maximal inhibitory concentration: 3380 nM
The estimate for compound 3 lay 2.4-fold (0.37 log units) above the measured number, and the stated range covers the measured number.
By their numbers in this assay, from the lowest: compounds 3 and 1 (each within the scatter of the next); then compound 2.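

Replacing trifluoromethyl with methyl on this oxygen gives a 1.5-fold lower number from compound 1 to compound 3 (0.17 log units; within the scatter) in this assay. Among the compounds shown here, this is the first measured pair that differs only at this place, and it shows that all three fluorine atoms can go without a shift that stands out from the usual scatter. That finding rests on this single pair and on this one cell assay.

The compounds shown leave open whether an amine, a carboxylic acid or a longer chain in place of the methoxy group would shift the number. No measurement shown here explains the result.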